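Ethyl to allyl on the aromatic nitrogen: compound 3

A few compounds are considered here, and "the series" means these few. Any claim that something is new, unique, unknown or untested is made for them only; others in the source may bear on it.

Compound 1 `CCn1c(SCC(=O)c2ccccc2)nnc1-c1cc(OC)c(OC)c(OC)c1` stands lowest of the two measured compounds: in a functional assay on the whole organism (strain albino) for inhibition, with Rattus norvegicus as the target, read by paw edema, with a stated time of 5 h, at a dose of 0.28 mmol/kg by the oral route (on this read-out higher numbers stand for more inhibition at the one dose given (going by the name of the read-out) and lower numbers for less inhibition), compound 1 gives 59%. Compound 2 `CCn1c(SC/C(=N/O)c2ccccc2)nnc1-c1cc(OC)c(OC)c(OC)c1` differs from compound 1 only at the group on the saturated chain carbon bound to the sulfur; in this assay compound 2 gives 74%, and that single measured step, a number 15 percentage points higher from compound 1 to compound 2 (beyond the scatter), is the only one in hand. Compound 3 `C=CCn1c(SCC(=O)c2ccccc2)nnc1-c1cc(OC)c(OC)c(OC)c1` differs from compound 1 at another place: vinyl in place of methyl on a saturated chain carbon bound to an aromatic nitrogen, so that ethyl becomes allyl. Among the compounds with values here, no measured step touches the group on the aromatic nitrogen, and the step from compound 1 to compound 2 therefore bears only loosely on this change, giving no indication of size or direction. The expectation is a step that stays within the scatter. Compound 3 is accordingly expected to give about 59% in this assay, within 45% to 72%, which means an estimated step of no change at the digits printed from compound 1 to compound 3 (within the scatter).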

Compound 3, a percentage reported as inhibition, in the whole organism at one dose (the size of the read-out at that dose, not a potency): 60%
For compound 3 the middle estimate is 1 percentage points below the measured one; low and high end bracket the measured number.
By their numbers in this assay, from the lowest: compounds 1 and 3 (each within the scatter of the next); then compound 2.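

In this assay, within the data shown here, vinyl in place of methyl on a saturated chain carbon bound to an aromatic nitrogen gives a number 1 percentage points higher from compound 1 to compound 3 (within the scatter) and so provides the first reading at this place. With the rest of compound 1 held fixed, ethyl and allyl cannot be told apart on this read-out at the one dose given. Nothing available explains this result.

As far as these compounds go, how far this place accepts other groups remains open: a longer chain such as butyl, a benzyl group or a chain ending in an amine could each give a different reading. Also open, from the compounds shown here alone, is whether allyl on the aromatic nitrogen and the group that compound 2 carries on the saturated chain carbon bound to a sulfur would give a reading in line with each alone.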